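A Larger Ring on the Side Chain of Compound 3

The source may report more compounds than this note shows. Statements on the series, on what has been measured and on what is new or still open speak of the compounds shown alone.

Of the compounds shown here, three have been measured in an in vitro ADME assay on microsomes from liver (Homo sapiens) for metabolic stability, tested at 5 uM; on this read-out lower numbers stand for a shorter-lived compound and higher numbers for a longer-lived compound. Compound 1 `CC(C)CCn1nc(-c2cccs2)c(O)c(C2=NS(=O)(=O)c3cc(S(C)(=O)=O)ccc3N2)c1=O` gives 0.0933 h. Compound 2 `CC(C)CCn1nc(CC2CCC2)c(O)c(C2=NS(=O)(=O)c3cc(NS(C)(=O)=O)ccc3N2)c1=O` gives 0.417 h. Compound 3 `CS(=O)(=O)Nc1ccc2c(c1)S(=O)(=O)N=C(c1c(O)c(-c3cccs3)nn(CC3CCC3)c1=O)N2` gives only a limit of the assay rather than a number, > 1 h. Of the three values, that of compound 3 sits at the upper edge of what this assay reports (the limit of > 1 h in this assay, at which 1 of the 3 values shown sits).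

Compound 4 `CS(=O)(=O)Nc1ccc2c(c1)S(=O)(=O)N=C(c1c(O)c(-c3cccs3)nn(CCC3CCCCC3)c1=O)N2` has not yet been tested in this assay. It differs from compound 3 in a single place: cyclohexylmethyl in place of cyclobutyl on a saturated chain carbon bound to an aromatic nitrogen. For the measured compounds named here, no pair of measured compounds shows this same exchange of cyclobutyl for cyclohexylmethyl, so nothing measured here tells how large such a step is. Because compound 3 sits at the limit > 1 h, even a sizeable drop could still leave compound 4 at the same limit. The step from compound 3 to compound 4 is expected to be a modest shortening of the half-life, an at least 1.2-fold lower number from compound 3 to compound 4 (0.09 log units; that floor lies within the scatter), though staying within the scatter is also possible. Compound 4 is therefore estimated to give 0.8 h, with a likely range from 0.3 h to 2 h.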

Compound 4, half-life: > 1 h
Compound 4 ended at the assay's limit; the forecaster's own chance of this, stated with the estimate: 40%; middle value at least 1.2-fold (0.09 log units) away from the limit.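

Compound 3 and compound 4 both stop at the upper limit of this assay, so no step between them can be read: the limit of > 1 h in this assay, at which 2 of the 4 values shown sit.

The compounds shown leave open how long either one truly lasts, and whether cyclohexylmethyl in place of cyclobutyl changes the half-life at all.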